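Cyclohexyl for Benzyl: Expected Permeability of Compound 4

The source may report more compounds than this note shows. Statements on the series, on what has been measured and on what is new or still open speak of the compounds shown alone.

In an ADME assay for permeability, using PAMPA, with a stated time of 30 min, at pH 7.4 (a higher number here means that the compound crosses the layer faster, a lower number that the compound crosses the layer more slowly), three compounds sharing one core have been measured:

compound 1 `Fc1ccc(-c2ccc3c(NCCCNCc4ccco4)ccnc3c2)cc1` gives 237 10^-6 cm/s
compound 2 `Fc1ccc(Cc2ccc3c(NCCCNCc4ccco4)ccnc3c2)c(Cl)c1` gives 23 10^-6 cm/s
compound 3 `c1ccc(CCc2ccc3c(NCCCNCc4ccco4)ccnc3c2)cc1` gives 23 10^-6 cm/s

Compound 3 sits level with compound 2 at the digits shown, and the two together hold the lowest numbers of the three; the step down from the highest number to one of them is a 10-fold lower number from compound 1 to compound 3 (1.01 log units; beyond the scatter), while the step down to the other is a 10-fold lower number from compound 1 to compound 2 (1.01 log units; beyond the scatter). Compound 4 `c1coc(CNCCCNc2ccnc3cc(CC4CCCCC4)ccc23)c1`, not yet measured, differs from compound 3 by cyclohexyl in place of benzyl on a saturated chain carbon bound to an aromatic carbon. Within the data shown here, the only measured step at that same chain carbon is no change at the digits printed from compound 2 to compound 3 (within the scatter), which stayed within the scatter. The two large steps both start from compound 1 and change the group on the aromatic carbon itself, so they do not speak to this change. Among the measured compounds shown here, no measured pair shows a non-aromatic ring entering in place of an aromatic one, so the expectation rests on the single step at that position, and compound 4 is expected to show no change at the digits printed from compound 3 to compound 4 (within the scatter). Compound 4 is therefore estimated at 23 10^-6 cm/s, within 10 10^-6 cm/s to 50 10^-6 cm/s.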

Compound 4, apparent permeability: 23 10^-6 cm/s
For compound 4 middle estimate and measured number coincide at the digits printed; low and high end bracket the measured number.
By their numbers in this assay, from the lowest: compounds 2, 3 and 4 (each within the scatter of the next); then compound 1.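

In this assay, cyclohexyl in place of benzyl on a saturated chain carbon bound to an aromatic carbon gives the first measured case of a non-aromatic ring entering for an aromatic one (no change at the digits printed from compound 3 to compound 4 (within the scatter)). Cyclohexyl in place of 2-chloro-4-fluorophenyl at that carbon reads the same (no change at the digits printed from compound 2 to compound 4 (within the scatter)), so this read-out does not separate these three end groups at this position. The large step remains tied to the group on the aromatic carbon, since cyclohexylmethyl in place of 4-fluorophenyl gives a 10-fold lower number from compound 1 to compound 4 (1.01 log units; beyond the scatter) and matches the two earlier large steps at the digits printed.

From the compounds shown here alone, whether an amine, a carboxylic acid or a longer chain at this place would also leave the number level stays open. No measurement at hand accounts for these numbers.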